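A few compounds are considered here, and "the series" means these few. Any claim that something is new, unique, unknown or untested is made for them only; others in the source may bear on it.

Working notes on the series.

Compound 2 `CCN(CCC1CC1)Cc1c(C(F)(F)F)nc2n(-c3c(C)cc(C)cc3C)c(Cl)cn12` carries the shared core with a (2-cyclopropylethyl)(ethyl)amino group on a saturated chain carbon bound to an aromatic carbon. In an assay on cells for displacement of a labelled ligand from corticotropin-releasing factor receptor 1 (Homo sapiens), with a stated time of 100 min (on this read-out lower numbers stand for stronger inhibition and higher numbers for weaker inhibition), compound 2 gives 13 nM. Within the data shown here, its only measured neighbour is compound 1 `Cc1cc(C)c(-n2c(Cl)cn3c(CN(CCC(F)(F)F)CC4CC4)c(C(F)(F)F)nc23)c(C)c1`, which in this assay gives 16 nM; the two numbers sit within the scatter of one another, so neither can be placed above the other. Among the measured compounds shown here, the single step on record, a 1.2-fold lower number from compound 1 to compound 2 (0.09 log units; within the scatter), is the one swap of amine substituents seen so far and it left the read-out essentially unchanged.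

Compound 3 `Cc1cc(C)c(-n2c(Cl)cn3c(CN4CCCC4c4ccccc4)c(C(F)(F)F)nc23)c(C)c1` differs from compound 2 by 2-phenylpyrrolidin-1-yl in place of (2-cyclopropylethyl)(ethyl)amino on a saturated chain carbon bound to an aromatic carbon. For the measured compounds named here, this replaces an open-chain dialkylamine with a ring-bound amine bearing a phenyl group, a change of a different kind from the one measured step, which only exchanged the two chain substituents. Going by the values given here, the one precedent bearing on the amine position therefore suggests tolerance at this site, but it does not cover a ring-closed, aryl-bearing amine, so the expectation is held loosely. For compound 3 the expected step in this assay is a 1.7-fold higher number from compound 2 to compound 3 (0.23 log units; within the scatter), without a confident direction. Compound 3 is estimated at 22 nM, with a range from 6 nM to 80 nM.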

Compound 3, inhibition constant: > 7000 nM
Compound 3: only a limit was reported (the forecaster's own chance of this, stated with the estimate: 3%); middle value at least 310-fold (2.50 log units) away from the limit.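

In this assay compound 3 is reported only as a limit and not as a number: the limit of > 7000 nM in this assay, at which 1 of the 3 values shown sits.

Even read from that limit, the change is large and beyond the scatter, with an at least 530-fold higher number from compound 2 to compound 3 (2.73 log units; beyond the scatter) and an at least 430-fold higher number from compound 1 to compound 3 (2.64 log units; beyond the scatter), so the amine on this saturated chain carbon bound to an aromatic carbon is not freely exchangeable, something the near-equal open-chain pair of compound 1 and compound 2 gave no sign of. The tolerance seen across those two open-chain amines therefore does not extend to 2-phenylpyrrolidin-1-yl, although this rests on a single ring-bound amine and supports no wider rule.

The entering group brings a five-membered non-aromatic ring and a six-membered aromatic ring together, and the compounds shown cannot separate the contribution of the ring-bound amine from that of the phenyl group. From the compounds shown here alone, an unsubstituted pyrrolidin-1-yl group and an open-chain benzyl(ethyl)amino group at the same place would pull these two apart, and the true value of compound 3 also remains unknown behind its limit.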